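A second chloro on a hydrazone that showed no activity

The source may hold more compounds than are shown below. What is called first, only, known or untested is meant among the compounds shown, and "the series" means these compounds.

All three measured compounds share one core and differ only in what sits on the outer aromatic ring. Compound 1 `COc1cc(/C=N/Nc2nc3ccccc3s2)ccc1O` carries a methoxy and a hydroxy; in a functional assay on HCT-8 cells (Homo sapiens) for cytotoxicity, read by MTT assay, with a stated time of 72 h (on this read-out higher numbers stand for weaker inhibition and lower numbers for stronger inhibition), compound 1 reaches only the limit of the assay, > 16700 nM, and no number. Compound 3 `CN(C)c1ccc(/C=N/Nc2nc3ccccc3s2)cc1` carries a dimethylamino; in this assay compound 3 likewise stops at the limit > 16800 nM. Compound 2 `Clc1ccc(/C=N/Nc2nc3ccccc3s2)cc1` carries a single chloro; in this assay compound 2 also gives only the limit > 17300 nM. Compound 2 therefore stands nowhere distinct: every value shown is a limit, and no value is separated from another. The step that the two limits leave unreadable from compound 2 to compound 3 cannot be read because the limit of > 17300 nM in this assay, at which 1 of the 3 values shown sits, and the limit of > 16800 nM in this assay, at which 1 of the 3 values shown sits, cap both ends of it.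

Compound 4 `Clc1ccc(/C=N/Nc2nc3ccccc3s2)c(Cl)c1` differs from compound 2 by chloro in place of hydrogen on an aromatic carbon, ortho to a large group and meta to a chloro group. Going by the values given here, only one measured step touches the outer ring, and it is unreadable; the limits (the limit of > 16700 nM in this assay, at which 1 of the 3 values shown sits), the limit of > 16800 nM in this assay, at which 1 of the 3 values shown sits, and the limit of > 17300 nM in this assay, at which 1 of the 3 values shown sits, give no direction at all. The writer therefore expects no step beyond the scatter in this assay, an estimated at least 1.0-fold lower number from compound 2 to compound 4 (0.00 log units; that floor lies within the scatter). For compound 4 the estimate is 17000 nM, between 8000 nM and 50000 nM, and most probably again only a limit.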

Compound 4, half-maximal inhibitory concentration: > 15500 nM
Compound 4 gave a limit, no number (the forecaster's own chance of this, stated with the estimate: 85%); the middle value lies beyond the limit too.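

In this assay the step from compound 2 to compound 4 cannot be read, since compound 4, like compound 2, gives a limit and not a number: the limit of > 15500 nM in this assay, at which 1 of the 4 values shown sits. Compounds 1, 2, 3 and 4, all limits, leave open whether any group on the outer aromatic ring of the shared core can yield a measurable number in this assay.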